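Adding a Second Methyl to the Fluorinated Indole Acid

The compounds below may be only part of what the source reports. "The series", "measured", "known", "first", "only" and "open" are said of these compounds alone.

Compound 1 `Cc1cc(C(=O)n2c(C)c(CC(=O)O)c3ccccc32)c(C)cc1OC[C@@H]1CN(C)c2ccccc2O1` has no result in a functional assay on CHO cells for antagonist activity at prostaglandin D2 receptor (Mus musculus), read by cAMP accumulation and immunoassay, with a stated time of 10 min, in the presence of a further agent that is not named here (on this read-out higher numbers stand for weaker inhibition and lower numbers for stronger inhibition), where its entry reads "not determined" (no result reported). In this assay compound 2 `Cc1cc(OC[C@@H]2CN(C)c3ccccc3O2)ccc1C(=O)n1c(C)c(CC(=O)O)c2cc(F)ccc21` gives 3.2 nM, while compound 3 `Cc1cc(C(=O)n2c(C)c(CC(=O)O)c3cc(F)ccc32)ccc1OC[C@@H]1CN(C)c2ccccc2O1` gives 42 nM, the highest number of the two single values, and its gap to compound 2 lies beyond the scatter. Compound 4 `Cc1cc(C(=O)n2c(C)c(CC(=O)O)c3cc(F)ccc32)c(C)cc1OC[C@@H]1CN(C)c2ccccc2O1` differs from compound 3 by methyl in place of hydrogen on an aromatic carbon. Among the measured compounds shown here, no measured pair shows this exact step, so the direction must be inferred. Since compound 2, which places its methyl differently, gives 3.2 nM, compound 4 is expected to move toward lower numbers, by a step of about a 5.3-fold lower number from compound 3 to compound 4 (0.72 log units; beyond the scatter). Compound 4 is therefore estimated at 8 nM, with a range from 2 nM to 40 nM.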

Compound 4, half-maximal inhibitory concentration: 2.8 nM
Compound 4: the middle estimate sits 2.9-fold (0.46 log units) above what was measured; measured number inside the range.
By their numbers in this assay, from the lowest: compounds 4 and 2 (each within the scatter of the next); then compound 3.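

In this assay, methyl in place of hydrogen para to a methyl group gives a 15-fold lower number from compound 3 to compound 4 (1.18 log units; beyond the scatter), so this aromatic carbon matters strongly when the ring carries only the methyl of compound 3. The same two-methyl compound set against the other single-methyl compound gives a 1.1-fold lower number from compound 2 to compound 4 (0.06 log units; within the scatter), so the second methyl brings no change beyond the scatter there, and the effect depends on which methyl is already present. Nothing shown explains this difference. The compounds shown leave open whether an ethyl or a methoxy group on this carbon would match methyl. They also leave open how much of the result rests on the fluorine.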